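The source may report more compounds than this note shows. Statements on the series, on what has been measured and on what is new or still open speak of the compounds shown alone.

Compound 1 `C=C(N=[N+]=[N-])c1cn(COCCO)c(=O)[nH]c1=O`: in a functional assay on Daudi cells (Homo sapiens) (on this read-out lower numbers stand for stronger inhibition and higher numbers for weaker inhibition), compound 1 gives only the assay limit > 50 ug/mL.
Compound 2 `C=C(N=[N+]=[N-])c1cn(COC(CO)CO)c(=O)[nH]c1=O`: in this assay compound 2 gives only the assay limit > 50 ug/mL.

Compound 2 therefore stands at the limit of the read-out, not at a number. Every value shown sits at the limit of > 50 ug/mL in this assay, at which 2 of the 2 values shown sit. Compound 3 `C=C(N=[N+]=[N-])c1cn(CCC(CO)CO)c(=O)[nH]c1=O` differs from compound 2 by 3-hydroxy-2-(hydroxymethyl)propyl in place of 2-hydroxy-1-(hydroxymethyl)ethoxy on a saturated chain carbon bound to an aromatic nitrogen. Within the data shown here, the one measured step, a step that the two limits leave unreadable from compound 1 to compound 2, is left unreadable by the two limits, so no step of readable size bears on this change. Compound 3 is accordingly expected to remain at the limit, with an estimated step that the limit leaves unreadable from compound 2 to compound 3. The estimate for compound 3 is 60 ug/mL, ranging from 25 ug/mL to 200 ug/mL.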

Compound 3, half-maximal inhibitory concentration: > 50 ug/mL
Compound 3: a limit, no number (the forecaster's own chance of this, stated with the estimate: 85%); the middle value is on the limit's open side.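

In this assay compound 3 gives only a limit, > 50 ug/mL, so its steps from compound 1 and compound 2 cannot be read. How strongly any of these compounds inhibits remains open: the limit of > 50 ug/mL in this assay, at which 3 of the 3 values shown sit.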